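This account rests on a few compounds, and the source may have more. Where it says the series, first, only, none or still open, it means among the compounds named here.

Compound 1 `CCC(C)n1ncn(-c2ccc(N3CCN(c4ccc(OC[C@@H]5CO[C@@](CC)(c6ccc(Cl)cc6Cl)O5)cc4)CC3)cc2)c1=O`: 353 nM
Compound 2 `CCC(C)n1ncn(-c2ccc(N3CCN(c4ccc(OC[C@@H]5CO[C@@](Cn6nc(C)nc6C)(c6ccc(Cl)cc6Cl)O5)cc4)CC3)cc2)c1=O`: 221 nM
Compound 3 `CCC(C)n1ncn(-c2ccc(N3CCN(c4ccc(OC[C@@H]5CO[C@@](Cn6ccnc6C)(c6ccc(Cl)cc6Cl)O5)cc4)CC3)cc2)c1=O`: 173 nM

These numbers come from a functional assay on HUVEC cells (Homo sapiens), read by scintillation counting and thymidine incorporation, with a stated time of 24 h; a higher number here means a weaker inhibitor, a lower number a stronger inhibitor. Compound 3 sits close to its nearest neighbour, with a 1.3-fold lower number from compound 2 to compound 3 (0.11 log units; within the scatter), and apart from its furthest, with a 2.0-fold lower number from compound 1 to compound 3 (0.31 log units; beyond the scatter).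

Compound 4 `CCc1nccn1C[C@@]1(c2ccc(Cl)cc2Cl)OC[C@@H](COc2ccc(N3CCN(c4ccc(-n5cnn(C(C)CC)c5=O)cc4)CC3)cc2)O1` differs from compound 3 by methyl in place of hydrogen on a saturated chain carbon bound to an aromatic carbon, which turns 2-methyl-1H-imidazol-1-yl into 2-ethyl-1H-imidazol-1-yl. Going by the values given here, no measured step tests this exact change. The closest evidence is swaps of the whole side group, and these were small, including a 1.6-fold lower number from compound 1 to compound 2 (0.20 log units; within the scatter). A much smaller edit should therefore shift this assay little, and no direction can be favoured. The expected result is a 1.0-fold lower number from compound 3 to compound 4 (0.01 log units; within the scatter). For compound 4 the estimate is 170 nM, with an expected range from 90 nM to 330 nM.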

Compound 4, half-maximal inhibitory concentration: 224 nM
The estimate for compound 4 lay 1.3-fold (0.12 log units) below the measured number; the measured number falls inside the stated range.
By their numbers in this assay, from the lowest: compounds 3, 2, 4 and 1 (each within the scatter of the next, the first and the last beyond it).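

In this assay, going from 2-methyl-1H-imidazol-1-yl to 2-ethyl-1H-imidazol-1-yl gives a 1.3-fold higher number from compound 3 to compound 4 (0.11 log units; within the scatter), the only direct test of this added methyl among these compounds, and it stays within the scatter. The ethyl compound also lies within the scatter of the other two, with a 1.0-fold higher number from compound 2 to compound 4 (0.01 log units; within the scatter) and a 1.6-fold lower number from compound 1 to compound 4 (0.20 log units; within the scatter), although compound 3 stands beyond the scatter of compound 1. No accompanying measurement explains these steps. Going by these compounds, whether a longer chain such as propyl, or an amine, at this position would give a step beyond the scatter remains open.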